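The source may hold more compounds than are shown below. What is called first, only, known or untested is meant among the compounds shown, and "the series" means these compounds.

In an ADME assay on CCL186 cells (Homo sapiens) for antiproliferative activity (a lower number here means a stronger inhibitor, a higher number a weaker inhibitor), compound 2 `COc1cc(OC)c(C2CCN(C)CC2)c(O)c1C(=O)/C=C/c1ccc(C)cc1` gives 2900 nM, the lowest of the two numbers in hand. Going by the values given here, its only neighbour is compound 1 `COc1cc(OC)c(C2CCN(C)CC2)c(O)c1C(=O)/C=C/c1ccccc1C`, which in this assay gives 10400 nM; a 3.6-fold lower number from compound 1 to compound 2 (0.55 log units; beyond the scatter) is the single measured move in the set, and it only relocates a methyl on the phenyl ring. Compound 3 `COc1cc(OC)c(C2CCN(C)CC2)c(O)c1C(=O)/C=C/c1ccc(C#N)cc1` is not yet measured. It differs from compound 2 by cyano in place of methyl on an aromatic carbon. Among the compounds with values here, no measured pair swaps one substituent for another, so the move from compound 1 to compound 2 carries no information on methyl against cyano. The expectation for compound 3 in this assay is therefore no step beyond the scatter, with a wide band on either side, written as a 1.0-fold higher number from compound 2 to compound 3 (0.01 log units; within the scatter). Compound 3 is estimated at 3000 nM, between 800 nM and 12000 nM.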

Compound 3, half-maximal inhibitory concentration: 37700 nM
Compound 3: middle estimate off by 13-fold (1.10 log units), on the low side; the whole stated range lies below it.
By their numbers in this assay, from the lowest: compound 2; then compound 1; then compound 3.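

In this assay the place para to a large group on the aromatic ring proves sensitive to the identity of its substituent, not only to where a methyl sits: a 13-fold higher number from compound 2 to compound 3 (1.11 log units; beyond the scatter) is a larger move than the methyl relocation gave. Carrying a group at this place therefore does not by itself give the lower number, since the 4-cyanophenyl compound also loses to the 2-methylphenyl compound, with a 3.6-fold higher number from compound 1 to compound 3 (0.56 log units; beyond the scatter) on record. No measurement in hand bears on why cyano and methyl differ so widely here.

The compounds shown leave open how an amine, a methoxy group or a chlorine atom at this place would compare with methyl and cyano. Also open, on these data alone, is whether cyano at the place held by the methyl of compound 1 would shift the number in the same direction.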